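Adding 4-methylphenyl to a compound at the assay limit

The source may report more compounds than this note shows. Statements on the series, on what has been measured and on what is new or still open speak of the compounds shown alone.

Compound 2 `O=C1COc2ccc(-c3cnc(Cl)c(NS(=O)(=O)c4ccc(F)cc4)c3)cc2N1` offers no number to start from. In a functional assay on A-375 cells (Homo sapiens) for antiproliferative activity, read by MTT assay, with a stated time of 72 h (on this read-out lower numbers stand for stronger inhibition and higher numbers for weaker inhibition), compound 2 gives > 40000 nM, which is a limit of the assay and not a measured value. Compound 1 `COc1cccc(N2C(=O)COc3ccc(-c4cnc(Cl)c(NS(=O)(=O)c5ccc(F)cc5)c4)cc32)c1`, which carries 3-methoxyphenyl on the same nitrogen, gives > 40000 nM, also a limit. Together they make up (the limit of > 40000 nM in this assay, at which 2 of the 2 values shown sit), so no measured value in this small set lies inside the range of the assay.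

Compound 3 `Cc1ccc(N2C(=O)COc3ccc(-c4cnc(Cl)c(NS(=O)(=O)c5ccc(F)cc5)c4)cc32)cc1` differs from compound 2 as follows: 4-methylphenyl in place of hydrogen on an amide-type nitrogen in a ring. Going by the values given here, the closest precedent is a step that the two limits leave unreadable from compound 1 to compound 2, with hydrogen in place of 3-methoxyphenyl on that same nitrogen. It runs the opposite way and involves a different phenyl group, and its size cannot be read. Among the compounds with values here, it shows only that compound 1, with its substituted phenyl, gives > 40000 nM. Nothing here therefore supports a gain or a loss, and the expected change is a number no higher from compound 2 to compound 3 (the limit leaves the size open), with no shift beyond the scatter anticipated in this assay. Compound 3 is estimated at 40000 nM, with an expected range of 12000 nM to 80000 nM, and a report as a limit is the likeliest outcome.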

Compound 3, half-maximal inhibitory concentration: 38900 nM
Beside the measured number, compound 3's estimate is 1.0-fold (0.01 log units) above it; measured number inside the range.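

Going by these compounds alone, with compound 3, the amide-type nitrogen in the ring yields the only number in this assay that is a measured value and not a limit, so this position can now be read at one point, with 4-methylphenyl on it. Putting 4-methylphenyl in place of hydrogen gives an at least 1.0-fold lower number from compound 2 to compound 3 (0.01 log units; that floor lies within the scatter), and putting it in place of 3-methoxyphenyl gives an at least 1.0-fold lower number from compound 1 to compound 3 (0.01 log units; that floor lies within the scatter); these are floors only, and the true size of either step stays hidden. The result therefore establishes a reading for this change but no gain that can be claimed for it, and the set as a whole still stays at the edge of the range of the assay: the limit of > 40000 nM in this assay, at which 2 of the 3 values shown sit.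

As far as these compounds go, how far the two compounds at the limit really lie from compound 3 remains open, and so does any comparison between 4-methylphenyl and 3-methoxyphenyl as groups on this nitrogen. Also open, from the compounds shown here alone, is whether an amine or a carboxylic acid on that phenyl ring, or a longer chain on the same nitrogen, would move the number beyond the scatter.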